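This account rests on a few compounds, and the source may have more. Where it says the series, first, only, none or still open, it means among the compounds named here.

Compound 1 `FC(F)(F)c1ccc(Nc2ncnc3sc(Nc4c(Cl)cccc4Cl)nc23)cc1` has, in a functional assay on HEK293 cells for antagonist activity at transient receptor potential cation channel subfamily V member 1 (Rattus norvegicus), read by calcium flux (a higher number here means a weaker inhibitor, a lower number a stronger inhibitor), the lower of the two numbers measured: compound 1 gives 3 nM. Compound 2 `FC(F)(F)c1ccc(Nc2ncnc3sc(Nc4ccccc4C(F)(F)F)nc23)cc1` gives 37 nM, a step of a 12-fold higher number from compound 1 to compound 2 (1.09 log units; beyond the scatter). Compound 3 `O=C(c1ccc(Nc2ncnc3sc(Nc4c(Cl)cccc4Cl)nc23)cc1)N1CCCC1` reaches only a limit of this assay, > 5000 nM. Its step from compound 1, an at least 1600-fold higher number from compound 1 to compound 3 (3.22 log units; beyond the scatter), rests on (the limit of > 5000 nM in this assay, at which 1 of the 3 values shown sits). For the measured compounds named here, compound 4 `FC(F)(F)c1ccc(Nc2nc(N3CCC3)nc3sc(Nc4c(Cl)cccc4Cl)nc23)cc1` differs from compound 1 at a place no measured step touches: azetidin-1-yl in place of hydrogen on an aromatic carbon. Both measured steps were large, yet each changed a different part of the shared core, so neither guides this change directly. For compound 4 a modest weakening is expected, a step of a 3.3-fold higher number from compound 1 to compound 4 (0.52 log units; beyond the scatter). Compound 4 is therefore estimated at 10 nM, within a range from 2 nM to 60 nM.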

Compound 4, half-maximal inhibitory concentration: 25 nM
Beside the measured number, compound 4's estimate is 2.5-fold (0.40 log units) below it, within the range that was stated.
By their numbers in this assay, from the lowest: compound 1; then compounds 4 and 2 (each within the scatter of the next). At a limit, above all of these: compound 3.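

For the compounds shown here, the step of an 8.3-fold higher number from compound 1 to compound 4 (0.92 log units; beyond the scatter) in this assay gives the first reading at the aromatic carbon between two ring nitrogen atoms, a place the earlier compounds left unchanged. Putting azetidin-1-yl there weakens inhibition, yet the loss is modest, so this position accepts a four-membered non-aromatic ring while compound 4 remains an inhibitor. Nothing shown here explains the size of this step. Still open, from the compounds shown here alone, is how a methyl group, an open-chain dimethylamino group or a larger pyrrolidine ring would behave on this same carbon.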